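The source may report more compounds than this note shows. Statements on the series, on what has been measured and on what is new or still open speak of the compounds shown alone.

Measured so far in an assay on HEK293 cells for inhibition of Fatty-acid amide hydrolase 1 (Homo sapiens), read by fluorescence; a lower number here means a stronger inhibitor, a higher number a weaker inhibitor:

- compound 1 `COc1ccc(-c2ccc3oc(NC4CCCCC4)nc3c2)cc1C`, 228 nM
- compound 2 `Cn1ncc2c(-c3ccc4oc(NC5CCCCC5)nc4c3)cccc21`, 52 nM
- compound 3 `Cn1ccc2cc(-c3ccc4oc(Nc5ccccc5)nc4c3)ccc21`, 48 nM

Compound 3 gives the lowest of the three numbers in this assay. Compound 2 sits within the scatter of it, so the two cannot be ordered; compound 1 stands beyond the scatter at the higher end.

Compound 4 `Cn1ccc2cc(-c3ccc4oc(Nc5cccnc5)nc4c3)ccc21` is the next one to measure in this assay. It differs from compound 3 in one place: pyridin-3-yl in place of phenyl on a nitrogen on an aromatic ring. Within the data shown here, no measured pair tells what such a change does here, so the direction is open; the step is expected to be small, likely none beyond the scatter. For compound 4 the estimate in this assay is 60 nM, range 20 nM to 180 nM, which is expected to mean a step of a 1.3-fold higher number from compound 3 to compound 4 (0.10 log units; within the scatter).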

Compound 4, half-maximal inhibitory concentration: 226 nM
The estimate for compound 4 lay 3.8-fold (0.58 log units) below the measured number; measured number above the stated range.
By their numbers in this assay, from the lowest: compounds 3 and 2 (each within the scatter of the next); then compounds 4 and 1 (each within the scatter of the next).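

In this assay, among these compounds, the group on this nitrogen is not interchangeable: anilino to (pyridin-3-yl)amino, a single ring carbon exchanged for nitrogen, gives the first single-place step (a 4.7-fold higher number from compound 3 to compound 4 (0.67 log units; beyond the scatter)). Of the two groups, phenyl gives the lower number at this place. Nothing measured here explains the rise.

From the compounds shown here alone, whether pyridin-4-yl or pyridin-2-yl gives a similar step remains open. Also open, going by these compounds, is whether the same exchange would raise the number when a different group replaces the methylated ring system of compound 3.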